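Removing the chloro: expected effect on cell tolerance

This account rests on a few compounds, and the source may have more. Where it says the series, first, only, none or still open, it means among the compounds named here.

In an ADME assay on MDCK cells (Canis lupus familiaris) for cytotoxicity (a higher number here means that more compound is tolerated, a lower number that less compound is tolerated), compound 2 `Cn1ccnc1Sc1cnc(C(C)(C)C)nc1-c1cc(Cl)ccc1O` gives 111000 ug/mL, the upper of the two numbers obtained so far; compound 1 `Cn1ccnc1Sc1cnc(-c2ccc(N)cc2)nc1-c1ccccc1O` gives 80100 ug/mL, a gap within the scatter. Compound 3 `Cn1ccnc1Sc1cnc(C(C)(C)C)nc1-c1ccccc1O` differs from compound 2 by hydrogen in place of chloro on an aromatic carbon. For the measured compounds named here, no measured pair shows this exchange, so no step beyond the scatter is expected in this assay, in either direction. Compound 3 is expected to give 95000 ug/mL, with a range from 50000 ug/mL to 180000 ug/mL. The expected step is a 1.2-fold lower number from compound 2 to compound 3 (0.07 log units; within the scatter).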

Compound 3, half-maximal cytotoxic concentration: 194000 ug/mL
The estimate for compound 3 lay 2.0-fold (0.31 log units) below the measured number; the whole stated range lies below it.
By their numbers in this assay, from the lowest: compounds 1, 2 and 3 (each within the scatter of the next, the first and the last beyond it).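

In this assay removing the chloro para to a hydroxy group gives a 1.7-fold higher number from compound 2 to compound 3 (0.24 log units; within the scatter) and so shows that hydrogen at this position causes no step beyond the scatter. Tert-butyl in place of 4-aminophenyl gives a 2.4-fold higher number from compound 1 to compound 3 (0.38 log units; beyond the scatter) and is the first step in the series beyond the scatter, though a modest one. No measured evidence bears on either step.

Open, going by these compounds, is how a fluoro, a methoxy or an amine at the chloro position would compare with hydrogen and chloro. Also open, on these data alone, is whether the tert-butyl step holds with the chloro in place.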